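Adding propyl to an aromatic nitrogen of compound 3

A few compounds are considered here, and "the series" means these few. Any claim that something is new, unique, unknown or untested is made for them only; others in the source may bear on it.

Measured so far in a functional assay on MV4-11 cells (Homo sapiens) for inhibition, read by resazurin assay, with a stated time of 72 h; on this read-out lower numbers stand for stronger inhibition of growth and higher numbers for weaker inhibition of growth:
- compound 1 `COc1ccc(Nc2nccc(-c3c[nH]c4ccccc34)n2)c(OC(F)F)c1` gives 4770 nM
- compound 2 `CNc1nc(C)c(-c2ccnc(Nc3ccc(OC)cc3OC)n2)s1` gives 300 nM
- compound 3 `COc1ccc(Nc2nccc(-c3c[nH]c4ccccc34)n2)c(OC)c1` gives 600 nM

Compound 3 (600 nM) lies within the usual scatter of compound 2 (300 nM), so these two cannot be ranked. The gap to compound 1 is larger. The data show an 8.0-fold lower number from compound 1 to compound 3 (0.90 log units; beyond the scatter) with methyl in place of difluoromethyl on an oxygen on an aromatic ring, and this lies beyond the scatter.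

Compound 4 `CCCn1cc(-c2ccnc(Nc3ccc(OC)cc3OC)n2)c2ccccc21` differs from compound 3 by a single change, propyl in place of hydrogen on an aromatic nitrogen. Going by the values given here, no measured compound carries anything other than hydrogen on that nitrogen. Among the compounds with values here, the one measured step sits at a different place, on an oxygen, so its size cannot simply be carried over and it gives no direction here. With so little evidence, the cautious expectation is a 1.3-fold higher number from compound 3 to compound 4 (0.12 log units; within the scatter) in this assay and thus no clear change beyond the scatter, although a larger move either way remains possible. The estimated value for compound 4 is 800 nM (expected range 200 nM to 3500 nM).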

Compound 4, concentration for 50% growth inhibition: 3620 nM
The estimate for compound 4 lay 4.5-fold (0.66 log units) below the measured number; measured number outside the range, above it.
By their numbers in this assay, from the lowest: compounds 2 and 3 (each within the scatter of the next); then compounds 4 and 1 (each within the scatter of the next).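

In this assay, going by these compounds alone, the nitrogen of the five-membered aromatic ring carries something other than hydrogen for the first time, and the result is a 6.0-fold higher number from compound 3 to compound 4 (0.78 log units; beyond the scatter) when propyl takes the place of that hydrogen. Within the data shown here, this is the first sign that the position is not a neutral place for change: on this core, growth inhibition is weaker with propyl than with hydrogen, a difference larger than the usual scatter. The earlier step, made on an oxygen, could not show this, and no measurement shown here explains why the number rises.

One pair cannot separate the effect of losing that hydrogen from the effect of adding this particular chain. As far as these compounds go, it remains open whether methyl, a longer chain, or a chain ending in an amine or a carboxylic acid on the same nitrogen would keep the growth inhibition of compound 3 or weaken it as propyl does.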